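A few compounds are considered here, and "the series" means these few. Any claim that something is new, unique, unknown or untested is made for them only; others in the source may bear on it.

Measured so far:
- compound 1, `Cc1ccc(CNc2nc(N)nc(-c3ccccc3CO)n2)cc1`: 4.38
- compound 2, `CC(C)Oc1ccc(CNc2nc(N)nc(-c3ccccc3CO)n2)cc1`: 4.99

Compound 2 stands at the top of the two numbers available in a functional assay on cells for positive allosteric modulation of G-protein coupled receptor 68 (Homo sapiens), read by a luciferase reporter and cAMP accumulation, with a stated time of 30 min, at pH 6.8 and pH 8.3, in the presence of a further agent that is not named here; a lower number here means a less potent compound, a higher number a more potent compound, by a factor of ten per unit of this negative logarithm. Within the data shown here, its nearest neighbour is compound 1, and the one comparison in hand, a number 0.61 log units higher from compound 1 to compound 2 (beyond the scatter), comes from an isopropoxy group in place of a methyl group on an aromatic carbon.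

Compound 3 is `Nc1nc(NCc2ccc(OC3CC3)cc2)nc(-c2ccccc2CO)n1`, not yet measured. It differs from compound 2 in one place: cyclopropyl in place of isopropyl on an oxygen on an aromatic ring. The aromatic ring, its oxygen and the rest of the shared core are kept; only the three-carbon group on that oxygen changes from an open chain to a three-membered ring.

Among the measured compounds shown here, no measured step bears directly on this exchange. For the measured compounds named here, the only step known, from compound 1 to compound 2, concerns what is attached to the aromatic carbon, not the shape of a group already sitting on the oxygen, so it gives no direction for compound 3. Compound 3 is therefore expected to stay close to compound 2, with an estimated step of a number 0.01 log units higher from compound 2 to compound 3 (within the scatter) in this assay, within the scatter. The estimate for compound 3 in this assay is 5, between 4.5 and 5.5.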

Compound 3, negative logarithm of the antagonist equilibrium constant: 5.07
Estimate against measurement, compound 3: 0.07 log units below; low and high end bracket the measured number.
By their numbers in this assay, from the lowest: compound 1; then compounds 2 and 3 (each within the scatter of the next).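

In this assay, closing the open isopropyl chain into a cyclopropyl ring on an oxygen on an aromatic ring gives a number 0.08 log units higher from compound 2 to compound 3 (within the scatter), so at this place the two groups, each of three carbons, cannot be told apart by their numbers. The comparison with the methyl compound now rests on two different groups on that oxygen rather than on isopropoxy alone: cyclopropyloxy in place of methyl on an aromatic carbon gives a number 0.69 log units higher from compound 1 to compound 3 (beyond the scatter), a step of the same modest kind as the one seen before. Nothing at hand gives a reason for either step or for the likeness of the two groups.

Still open, as far as these compounds go, is whether a cyclobutyl group or a longer chain such as butyl on the same oxygen would stay level with compound 2 and compound 3 or fall away from them. Also open, from the compounds shown here alone, is what a hydroxyl group or an amine on that aromatic carbon would give, with no carbon group beyond it, and all three compounds share the same core, so nothing here speaks to changes elsewhere.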